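Amide substituent on the shared core: compound 4

The source may hold more compounds than are shown below. What is called first, only, known or untested is meant among the compounds shown, and "the series" means these compounds.

The three measured compounds share one core and differ only in the group on the carbonyl carbon. Compound 1 `CCOC(=O)CN(C)C(=O)c1ccc(C(CC)(CC)c2ccc(OCC(=O)C(C)(C)C)c(C)c2)n1CC` gives in an assay on HL-60 cells for agonist activity at vitamin D3 receptor (Homo sapiens), read by microscopy, with a stated time of 96 h (a higher number here means that more compound is needed for the effect, a lower number that less compound is needed), only a limit, > 50000 nM (the limit of > 50000 nM in this assay, at which 1 of the 3 values shown sits). Compound 2 `C#CC(C)OC(=O)c1ccc(C(CC)(CC)c2ccc(OCC(=O)C(C)(C)C)c(C)c2)n1CC` gives 210 nM, and compound 3 `CC[C@@H](C)[C@H](NC(=O)c1ccc(C(CC)(CC)c2ccc(OCC(=O)C(C)(C)C)c(C)c2)n1CC)C(=O)O` gives 10 nM, the lowest of the two numbers; the nearest is compound 2, with a 21-fold lower number from compound 2 to compound 3 (1.32 log units; beyond the scatter). The other steps are an at least 230-fold lower number from compound 1 to compound 2 (2.37 log units; beyond the scatter) and an at least 5000-fold lower number from compound 1 to compound 3 (3.69 log units; beyond the scatter).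

Compound 4 `CCn1c(C(=O)Nc2cccc(C(F)(F)F)c2)ccc1C(CC)(CC)c1ccc(OCC(=O)C(C)(C)C)c(C)c1` makes a further change at the same position: 3-(trifluoromethyl)phenyl in place of 1-carboxy-2-methylbutyl on an amide-type nitrogen. All three measured steps bear on it, since each alters this carbonyl substituent and each was large. Among the compounds with values here, the step from the 1-carboxy-2-methylbutyl amide to an aryl amide has no measured counterpart, so the expectation rests on the spread seen so far: compound 3 sits lowest, and every other substituent tried here gave a clearly higher number or a limit. A higher number than compound 3 is therefore expected, of uncertain size. For compound 4 the estimated value in this assay is 150 nM, within 20 nM to 2000 nM. This estimate corresponds to an expected step of a 15-fold higher number from compound 3 to compound 4 (1.18 log units; beyond the scatter).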

Compound 4, half-maximal effective concentration: > 50000 nM
Compound 4 ended at the assay's limit; the forecaster's own chance of this, stated with the estimate: 15%; middle value at least 330-fold (2.52 log units) from the limit.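

An amide on the carbonyl carbon is not enough on its own to give the low number of compound 3: placing 3-(trifluoromethyl)phenyl on the amide-type nitrogen instead of 1-carboxy-2-methylbutyl gives an at least 5000-fold higher number from compound 3 to compound 4 (3.69 log units; beyond the scatter). This aryl amide also compares poorly with the (1-methylprop-2-yn-1-yl)oxy group, with an at least 230-fold higher number from compound 2 to compound 4 (2.37 log units; beyond the scatter). Compound 4 joins compound 1 at the assay limit, so the step between those two cannot be read: the limit of > 50000 nM in this assay, at which 2 of the 4 values shown sit.

The compounds shown do not separate the contribution of the carboxylic acid from that of the branched chain, since both leave together in this change. A 2-methylbutyl amide without the carboxylic acid, or a phenyl amide carrying a carboxylic acid, would begin to tell these apart.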